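Cytotoxicity notes: removing the chloro from compound 3

A few compounds are considered here, and "the series" means these few. Any claim that something is new, unique, unknown or untested is made for them only; others in the source may bear on it.

The series shares one core carrying two benzyl-type arms. Compound 1 `O=C1N(Cc2ccccc2Br)c2cccn2S(=O)(=O)N1Cc1cccc(F)c1`, compound 2 `O=C1N(Cc2ccccc2)c2cccn2S(=O)(=O)N1Cc1ccccc1` and compound 3 `O=C1N(Cc2cccc(Cl)c2)c2cccn2S(=O)(=O)N1Cc1cccc(F)c1` have been run in an ADME assay on MT4 cells (Homo sapiens) for cytotoxicity, read by MTT assay, with a stated time of 5 days; on this read-out higher numbers stand for lower toxicity in this test and lower numbers for higher toxicity in this test. Compound 1 reaches only a limit of the assay, > 269000 nM. Compound 2 gives 196000 nM. Compound 3 gives 208000 nM, and its number and that of compound 2 lie within the scatter of each other, so no order can be read between them. For the measured compounds named here, the one single-point step measured, an at least 1.2-fold lower number from compound 1 to compound 3 (0.11 log units; that floor lies within the scatter), runs against the limit of compound 1 the limit of > 269000 nM in this assay, at which 1 of the 3 values shown sits, and stays within the scatter.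

Compound 4 `O=C1N(Cc2ccccc2)c2cccn2S(=O)(=O)N1Cc1cccc(F)c1` is the next member; it differs from compound 3 by hydrogen in place of chloro on an aromatic carbon. Going by the values given here, no measured step removes a chloro outright, but the swap of 2-bromophenyl for 3-chlorophenyl in an at least 1.2-fold lower number from compound 1 to compound 3 (0.11 log units; that floor lies within the scatter) moved nothing beyond the scatter, and compound 3, giving 208000 nM, sits within the scatter of compound 2, carrying plain benzyl on both arms and giving 196000 nM. The expected step of a 1.0-fold lower number from compound 3 to compound 4 (0.02 log units; within the scatter) is therefore none beyond the scatter. Compound 4 is estimated at 200000 nM, within 110000 nM to 320000 nM.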

Compound 4, half-maximal cytotoxic concentration: > 288000 nM
Compound 4 gave a limit, no number; the forecaster's own chance of this, stated with the estimate: 25%; at least 1.4-fold (0.15 log units) between middle value and limit.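

In this assay, as far as these compounds go, hydrogen in place of chloro on this aromatic carbon gives an at least 1.3-fold higher number from compound 3 to compound 4 (0.14 log units; that floor lies within the scatter), so the loss of chloro from the 3-chlorobenzyl arm shows no step beyond the scatter, though its true size stays unknown. Fluoro in place of hydrogen on an aromatic carbon of the other arm gives an at least 1.4-fold higher number from compound 2 to compound 4 (0.16 log units; that floor lies within the scatter), which is likewise no step beyond the scatter. Compound 4 gives a limit and not a number, and that limit sets the floor of both steps: the limit of > 288000 nM in this assay, at which 1 of the 4 values shown sits.

The step from compound 1 to compound 4 joins two limits and cannot be read. From the compounds shown here alone, whether an amine or a carboxylic acid in place of hydrogen on this aromatic carbon would give a number clear of the scatter stays open.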